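Chloro on the hydroxyphenyl of compound 1

The source may report more compounds than this note shows. Statements on the series, on what has been measured and on what is new or still open speak of the compounds shown alone.

Compound 1 `NC(=O)c1cn(-c2ccc(O)cc2)c2cc(-c3ccncc3)ccc2c1=O` is the reference point of this pair. In an assay on isolated protein for inhibition of Calpain-1 catalytic subunit (Homo sapiens) (a higher number here means a weaker inhibitor, a lower number a stronger inhibitor), compound 1 gives 2000 nM, the lowest of the two numbers in hand. Within the data shown here, compound 2 `O=C(O)c1cn(-c2ccc(O)cc2)c2cc(-c3ccncc3)ccc2c1=O` gives 20000 nM in the same assay; the one measured step, a 10-fold higher number from compound 1 to compound 2 (1.00 log units; beyond the scatter), concerns hydroxy in place of amino on a carbonyl carbon and leaves the aryl part of the molecule untouched. Compound 3 `NC(=O)c1cn(-c2ccc(O)c(Cl)c2)c2cc(-c3ccncc3)ccc2c1=O` differs from compound 1 by chloro in place of hydrogen on an aromatic carbon. Among the measured compounds shown here, no measured step touches a substituent on that ring, so the data in hand give no direction for this change; the working expectation for compound 3 is a step of about a 1.3-fold lower number from compound 1 to compound 3 (0.12 log units; within the scatter) from compound 1, that is, none beyond the scatter. Compound 3 is accordingly estimated at 1500 nM, with a range from 400 nM to 6000 nM, the width reflecting the absence of any comparable step.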

Compound 3, half-maximal inhibitory concentration: 2000 nM
Beside the measured number, compound 3's estimate is 1.3-fold (0.12 log units) below it; the range from low to high includes it.
By their numbers in this assay, from the lowest: compounds 1 and 3 (each within the scatter of the next); then compound 2.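

In this assay, among these compounds, the change from 4-hydroxyphenyl to 3-chloro-4-hydroxyphenyl gives no change at the digits printed from compound 1 to compound 3 (within the scatter), the only measured step on this ring. This aromatic carbon, ortho to a hydroxy group, therefore accepts a chloro group with no shift beyond the scatter, whereas the change on the carbonyl carbon gives a 10-fold higher number from compound 1 to compound 2 (1.00 log units; beyond the scatter). No independent evidence bears on this result.

From the compounds shown here alone, whether fluoro, methyl, methoxy or an amine at the same carbon would also leave the number within the scatter remains open. Also open, going by these compounds, is whether the same chloro group would behave in the same way on the carboxylic acid of compound 2, and whether replacing the hydroxy group itself, for example with methoxy, would shift the number.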